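Methoxy for fluoro on the styryl ring of an oxime

The compounds below may be only part of what the source reports. "The series", "measured", "known", "first", "only" and "open" are said of these compounds alone.

Compound 1, `COc1ccc(/C=C/C(=N\O)c2ccc(OC)cc2)cc1`, gives 12300 nM in a functional assay (Mus musculus, strain Balb/c) for inhibition, read by ELISA, with a stated time of 72 h; a lower number here means a stronger inhibitor, a higher number a weaker inhibitor.
Compound 2, `O/N=C(\C=C\c1ccc(Cl)cc1)c1ccc(Cl)cc1`, gives 9150 nM in this assay.
Compound 3, `O/N=C(\C=C\c1ccc(F)cc1)c1ccc(Cl)cc1`, gives 10600 nM in this assay.

The three measured compounds share one core, an unsaturated oxime carrying two six-membered aromatic rings, and differ only in the groups on those rings. All three numbers lie close together. Compound 3 stands second highest of the three; its nearest neighbour is compound 2, and the step of a 1.2-fold higher number from compound 2 to compound 3 (0.06 log units; within the scatter) is within the scatter, while compound 1 is furthest away, also within the scatter of compound 3.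

Compound 4, `COc1ccc(/C=C/C(=N\O)c2ccc(Cl)cc2)cc1`, has not yet been measured. It differs from compound 3 in one place: methoxy in place of fluoro on an aromatic carbon. Among the compounds with values here, the only measured step, from compound 2 to compound 3, changes the same position and is within the scatter, and compound 1, which carries methoxy on both rings, sits within the scatter of compound 3 as well. Nothing here points to a step beyond the scatter in this assay, in either direction.

Compound 4 is therefore expected to give about 11000 nM, within a range from 5000 nM to 25000 nM, which means an expected step of a 1.0-fold higher number from compound 3 to compound 4 (0.02 log units; within the scatter).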

Compound 4, half-maximal inhibitory concentration: 5850 nM
Compound 4: middle estimate off by 1.9-fold (0.27 log units), on the high side; the range from low to high includes it.
By their numbers in this assay, from the lowest: compounds 4, 2, 3 and 1 (each within the scatter of the next, the first and the last beyond it).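

At this position, on an aromatic carbon para to a large group, methoxy can stand in for a halogen without a clear effect: methoxy in place of fluoro gives a 1.8-fold lower number from compound 3 to compound 4 (0.26 log units; within the scatter) and methoxy in place of chloro gives a 1.6-fold lower number from compound 2 to compound 4 (0.19 log units; within the scatter) in this assay, so these three groups cannot be told apart here. Within the data shown here, the one step that clears the scatter is a different change, chloro in place of methoxy, which gives a 2.1-fold lower number from compound 1 to compound 4 (0.32 log units; beyond the scatter) and is modest in size, so the shared core shows its first small but readable difference only with this pair. Nothing measured here explains why that step is larger than the other two.

Still open, as far as these compounds go, is whether a group of another kind at this position, such as an amine, a carboxylic acid or a longer chain like butoxy, would move the number clearly beyond the scatter. Also open, from the compounds shown here alone, is whether chloro in place of methoxy gives a step of similar size in other compounds with the shared core, as this finding rests on a single pair.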